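The source may report more compounds than this note shows. Statements on the series, on what has been measured and on what is new or still open speak of the compounds shown alone.

Measured compounds:
Compound 1 `Cc1ccc(-c2nn(-c3ccccc3)cc2-c2nc3ccccc3n2C(=O)c2ccccc2C)cc1` gives 176000 nM in an ADME assay on HEK-293T cells (Homo sapiens) for cytotoxicity, read by MTT assay, with a stated time of 24 h; on this read-out lower numbers stand for higher toxicity in this test and higher numbers for lower toxicity in this test.
Compound 2 `Cc1ccc(C(=O)n2c(-c3cn(-c4ccccc4)nc3-c3ccc(C(F)(F)F)cc3)nc3ccccc32)cc1` gives 169000 nM in this assay.
Compound 3 `Cc1ccc(-c2nn(-c3ccccc3)cc2-c2nc3ccccc3n2C(=O)c2cccc(C)c2)cc1` gives 195000 nM in this assay.

Within the data shown here, compound 3 stands among three numbers that all lie within the usual scatter of one another, so no compound can be set above or below the others on these data. Among the measured compounds shown here, the one step between compounds that differ in a single place is the move from compound 1 to compound 3, 3-methylphenyl in place of 2-methylphenyl on the carbonyl carbon, which was a 1.1-fold higher number from compound 1 to compound 3 (0.04 log units; within the scatter).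

Compound 4 `Cc1ccc(C(=O)n2c(-c3cn(-c4ccccc4)nc3-c3ccc(C)cc3)nc3ccccc32)cc1` has not yet been measured in this assay. It differs from compound 3 as follows: 4-methylphenyl in place of 3-methylphenyl on a carbonyl carbon. For the measured compounds named here, the step from compound 1 to compound 3, a change of the same kind on the same phenyl ring on the carbonyl carbon, is the only measured step that bears on it, and it stayed within the scatter. The expected step is therefore a 1.1-fold lower number from compound 3 to compound 4 (0.02 log units; within the scatter), with no direction that the data would support. On this basis compound 4 is estimated at 185000 nM, with a range from 120000 nM to 290000 nM in this assay.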

Compound 4, half-maximal cytotoxic concentration: 176000 nM
For compound 4 the middle estimate is 1.1-fold (0.02 log units) above the measured one; measured number inside the range.
By their numbers in this assay, from the lowest: compounds 2, 1, 4 and 3 (each within the scatter of the next).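

Compound 4 completes the set of methyl placements on the phenyl ring on the carbonyl carbon: 2-methylphenyl, 3-methylphenyl and 4-methylphenyl can now be compared directly in this assay. Neither new step on that ring leaves the scatter (a 1.1-fold lower number from compound 3 to compound 4 (0.04 log units; within the scatter); no change at the digits printed from compound 1 to compound 4 (within the scatter)), so the earlier single step within the scatter now has two more beside it, and no placement of the methyl can be set apart from another. Among these compounds, compound 4 also gives the first reading of a change elsewhere on the molecule, methyl in place of trifluoromethyl on an aromatic carbon, and that too stays within the scatter (a 1.0-fold higher number from compound 2 to compound 4 (0.02 log units; within the scatter)), while nothing measured alongside these numbers speaks to why the values lie so close together.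

The compounds shown leave open whether a group of another kind on the phenyl ring on the carbonyl carbon, such as an amine, a carboxylic acid or a longer alkyl chain, would give a number beyond the scatter from those of the methyl compounds. They also leave open whether a chlorine or a methoxy group in place of the methyl or trifluoromethyl on the aromatic carbon would do so in this assay.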